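This account rests on a few compounds, and the source may have more. Where it says the series, first, only, none or still open, it means among the compounds named here.

In a functional assay on HepG2 cells (Homo sapiens) for antiproliferative activity, read by MTT assay, with a stated time of 48 h (a lower number here means a stronger inhibitor, a higher number a weaker inhibitor), compound 2 `Brc1ccc(CNc2ccc3ncnc(Nc4cccc(Br)c4)c3c2)cc1` gives 1410 nM and compound 1 `Oc1ccccc1CNc1ccc2ncnc(Nc3cccc(Br)c3)c2c1` gives 1260 nM, so the two lie within the scatter of each other. Next is compound 3 `Brc1cccc(Nc2ncnc3ccc(NCc4ccccc4Br)cc23)c1`: 2-bromophenyl in place of 4-bromophenyl on a saturated chain carbon bound to a nitrogen on an aromatic ring. Going by the values given here, the one measured step at this place is a 1.1-fold higher number from compound 1 to compound 2 (0.05 log units; within the scatter), and it gives no sign of a large response. No shift beyond the scatter is therefore expected in this assay, and the expected change is a 1.0-fold lower number from compound 2 to compound 3 (0.00 log units; within the scatter). Compound 3 is estimated at 1400 nM, with an expected range of 550 nM to 3500 nM.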

Compound 3, half-maximal inhibitory concentration: 2760 nM
Estimate against measurement, compound 3: 2.0-fold (0.29 log units) below; low and high end bracket the measured number.
By their numbers in this assay, from the lowest: compounds 1, 2 and 3 (each within the scatter of the next, the first and the last beyond it).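

In this assay, 2-bromophenyl in place of 4-bromophenyl stays within the scatter, a 2.0-fold higher number from compound 2 to compound 3 (0.29 log units; within the scatter), so this pair shows no clear dependence on where the bromo sits on the phenyl ring. Bromo in place of hydroxy on an aromatic carbon gives the first step at this place beyond the scatter, a modest one: a 2.2-fold higher number from compound 1 to compound 3 (0.34 log units; beyond the scatter). No available evidence bears on the reason for this shift.

Still open, going by these compounds, is how an amine or a carboxylic acid on this phenyl ring would read in this assay. On these data alone, the effect of a longer chain at this place also remains open.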